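Replacing acetyl with furan-2-yl on compound 3

A few compounds are considered here, and "the series" means these few. Any claim that something is new, unique, unknown or untested is made for them only; others in the source may bear on it.

Of the compounds shown here, three built on one shared core have been tested in a functional assay on HeLa cells (Homo sapiens) for cytotoxicity; a lower number here means a stronger inhibitor, a higher number a weaker inhibitor: compound 1 (`C/C=C/C(=O)OC1=CC(=O)c2ccccc2C1=O`), compound 2 (`O=C(OC1=CC(=O)c2ccccc2C1=O)c1ccccc1`) and compound 3 (`CC(=O)OC1=CC(=O)c2ccccc2C1=O`). Compound 1 gives 37900 nM, compound 2 gives 55000 nM and compound 3 gives 62100 nM, so compound 3 sits within the scatter of both others.

The untested compound 4 (`O=C1C=C(Oc2ccco2)C(=O)c2ccccc21`) has furan-2-yl in place of acetyl on an oxygen on an unsaturated carbon.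

The nearest evidence comes from changes to the group on a carbonyl carbon. The measured steps are a 1.6-fold higher number from compound 1 to compound 3 (0.21 log units; within the scatter), a 1.1-fold higher number from compound 2 to compound 3 (0.05 log units; within the scatter) and a 1.5-fold higher number from compound 1 to compound 2 (0.16 log units; within the scatter), and all of them stay within the scatter. None replaces the whole acetyl, so they guide the expectation only loosely, and they favour no direction. No step beyond the scatter is expected, though the range must stay wide.

The estimated step is a 1.4-fold lower number from compound 3 to compound 4 (0.14 log units; within the scatter). The estimated value for compound 4 is 45000 nM, with an expected range from 14000 nM to 100000 nM.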

Compound 4, half-maximal inhibitory concentration: 37000 nM
For compound 4 the middle estimate is 1.2-fold (0.09 log units) above the measured one; the measured number falls inside the stated range.
By their numbers in this assay, from the lowest: compounds 4, 1, 2 and 3 (each within the scatter of the next).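

Compounds 1, 2 and 3 differ only in the group on a carbonyl carbon, so all three keep that carbonyl, whereas compound 4 has furan-2-yl directly on the oxygen on an unsaturated carbon. Even so, in this assay this change gives a 1.7-fold lower number from compound 3 to compound 4 (0.22 log units; within the scatter) and replacing (prop-1-en-1-yl)carbonyl with furan-2-yl gives a 1.0-fold lower number from compound 1 to compound 4 (0.01 log units; within the scatter), so among these compounds the number stays within the scatter with or without that carbonyl. Nothing measured here explains this lack of a clear shift.

On these data alone, whether an amine, a carboxylic acid or a longer chain on this oxygen would move the number beyond the scatter remains open. The compounds shown also vary only this one position, so the role of the shared core is untested here.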